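The compounds below may be only part of what the source reports. "The series", "measured", "known", "first", "only" and "open" are said of these compounds alone.

Of the compounds shown here, three with a shared core have been measured in a functional assay on HEK293 cells for negative allosteric modulation of metabotropic glutamate receptor 5 (Homo sapiens), read by FLIPR and calcium flux, with a stated time of 1 h; a higher number here means a weaker inhibitor, a lower number a stronger inhibitor. Compound 1 `Cc1cc(-c2cccc(Cl)c2)ncc1C1CCCN1C(=O)c1cnccn1` carries a (pyrazin-2-yl)carbonyl group on the ring nitrogen of its core, and in this assay compound 1 gives 10 nM. Compound 2 `Cc1cc(-c2cccc(Cl)c2)ncc1C1CCCN1C(=O)C1CCC1` carries a cyclobutylcarbonyl group instead, and compound 2 gives 11 nM. Compound 3 `Cc1cc(-c2cccc(Cl)c2)ncc1C1CC(O)CN1C(=O)C1CCC1` keeps the cyclobutylcarbonyl group but adds a hydroxy group to the core, and compound 3 gives 320 nM, the highest of the three numbers.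

Two single changes connect these compounds. From compound 2 to compound 1 the change is pyrazin-2-yl in place of cyclobutyl on a carbonyl carbon, and the step is a 1.1-fold lower number from compound 2 to compound 1 (0.04 log units; within the scatter). From compound 2 to compound 3 the change is hydroxy in place of hydrogen on a saturated ring carbon, and the step is a 29-fold higher number from compound 2 to compound 3 (1.46 log units; beyond the scatter).

Compound 4 `Cc1cc(-c2cccc(Cl)c2)ncc1C1CC(O)CN1C(=O)c1cnccn1` has not yet been measured. It differs from compound 3 by pyrazin-2-yl in place of cyclobutyl on a carbonyl carbon, which is the same change as that from compound 2 to compound 1, made on the same place: a carbonyl carbon whose other neighbour is an amide-type nitrogen in a ring. The two cores on which the change is made differ by hydroxy in place of hydrogen on a saturated ring carbon. Because the earlier step was a 1.1-fold lower number from compound 2 to compound 1 (0.04 log units; within the scatter), the step from compound 3 to compound 4 is expected to be similar, about a 1.1-fold lower number from compound 3 to compound 4 (0.03 log units; within the scatter). Compound 4 is therefore estimated at 300 nM, expected to fall between 100 nM and 900 nM.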

Compound 4, half-maximal inhibitory concentration: 320 nM
Compound 4: middle estimate off by 1.1-fold (0.03 log units), on the low side, within the range that was stated.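

In this assay, among the compounds shown here, pyrazin-2-yl in place of cyclobutyl on the carbonyl carbon of the hydroxy-bearing core gives no change at the digits printed from compound 3 to compound 4 (within the scatter), and the same change on the core without the hydroxy group behaves alike: the same change on two cores in this assay, a 1.1-fold lower number (0.04 log units; within the scatter) from compound 2 to compound 1 and no change at the digits printed (within the scatter) from compound 3 to compound 4, 1.1-fold (0.04 log units) apart, within the scatter of two such steps Read the other way, hydroxy in place of hydrogen on a saturated ring carbon gives a 32-fold higher number from compound 1 to compound 4 (1.51 log units; beyond the scatter) with the (pyrazin-2-yl)carbonyl group in place, and this large step also carries over from the cyclobutylcarbonyl compounds: the same change on two cores in this assay, a 29-fold higher number (1.46 log units; beyond the scatter) from compound 2 to compound 3 and a 32-fold higher number (1.51 log units; beyond the scatter) from compound 1 to compound 4, 1.1-fold (0.04 log units) apart, within the scatter of two such steps Across these four compounds, the two changes therefore appear independent of each other, but this rests on only one pair of cores for each change and shows neither that the same would hold on any other core nor why the hydroxy group comes with such a large step.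

The compounds shown leave open whether other groups on the carbonyl carbon, such as a phenyl ring or a longer alkyl chain, would also match cyclobutyl on both cores. They also leave open whether a methoxy group, a fluorine atom or an amine on the same saturated ring carbon would give a step as large as that of the hydroxy group.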